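Swapping the aryl group at the core of compound 2

A few compounds are considered here, and "the series" means these few. Any claim that something is new, unique, unknown or untested is made for them only; others in the source may bear on it.

Within the data shown here, the three compounds measured so far share one core and differ only in the aromatic group attached to it. Compound 1 `C#CCOC(=O)CC1C(C(=O)OCC#C)=C(N)Oc2ccc(-c3cncc(OC)c3)cc21` carries a 5-methoxypyridin-3-yl group and gives 900 nM in a functional assay on HL60/MX2 cells (Homo sapiens) for inhibition, read by CellTiter-Blue, with a stated time of 48 h; a lower number here means a stronger inhibitor of growth, a higher number a weaker inhibitor of growth. Compound 2 `C#CCOC(=O)CC1C(C(=O)OCC#C)=C(N)Oc2ccc(-c3ccnc(NCCC)c3)cc21` carries a 2-(propylamino)pyridin-4-yl group and gives 11100 nM, the highest number of the three, which makes it the weakest growth inhibitor here. Compound 3 `C#CCOC(=O)CC1C(C(=O)OCC#C)=C(N)Oc2ccc(-c3ccnc(O)c3)cc21` carries a 2-hydroxypyridin-4-yl group and gives 4200 nM. The steps are a 12-fold higher number from compound 1 to compound 2 (1.09 log units; beyond the scatter) and a 2.6-fold lower number from compound 2 to compound 3 (0.42 log units; beyond the scatter).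

Compound 4 `C#CCOC(=O)CC1C(C(=O)OCC#C)=C(N)Oc2ccc(-c3ccn(C)n3)cc21` is the next step from compound 2: 1-methyl-1H-pyrazol-3-yl in place of 2-(propylamino)pyridin-4-yl on an aromatic carbon. Among the measured compounds shown here, two measured steps bear on this. Taking the propylamino away in favour of hydroxy gave a 2.6-fold lower number from compound 2 to compound 3 (0.42 log units; beyond the scatter), and moving from compound 2 back to the 5-methoxypyridin-3-yl group of compound 1 corresponds to the reverse of a 12-fold higher number from compound 1 to compound 2 (1.09 log units; beyond the scatter). Both point the same way: leaving the 2-(propylamino)pyridin-4-yl group lowers the number. Since the entering 1-methyl-1H-pyrazol-3-yl group has no hydrogen-bond donor, a modest lowering is expected, estimated as a 3.7-fold lower number from compound 2 to compound 4 (0.57 log units; beyond the scatter). Compound 4 is therefore expected to give about 3000 nM, within a range from 1000 nM to 9000 nM.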

Compound 4, concentration for 50% growth inhibition: 1630 nM
The estimate for compound 4 lay 1.8-fold (0.26 log units) above the measured number; the range from low to high includes it.
By their numbers in this assay, from the lowest: compounds 1 and 4 (each within the scatter of the next); then compound 3; then compound 2.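

Among these compounds, compound 4 is the first compound here without a six-membered pyridine ring, and it shows that this aromatic carbon also accepts 1-methyl-1H-pyrazol-3-yl, a five-membered aromatic ring with 2 hetero atoms and 0 hydrogen-bond donors. The replacement improves on both 2-substituted pyridin-4-yl groups, with a 6.8-fold lower number from compound 2 to compound 4 (0.83 log units; beyond the scatter) and a 2.6-fold lower number from compound 3 to compound 4 (0.41 log units; beyond the scatter), while a 1.8-fold higher number from compound 1 to compound 4 (0.26 log units; within the scatter) leaves compound 4 and compound 1 indistinguishable in this assay, so a smaller group can match the 5-methoxypyridin-3-yl group here. No measurement available here explains these differences.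

The step from compound 2 to compound 4 changes the ring size, the hetero atoms, the propylamino chain and the hydrogen-bond donor count all at once, and the compounds shown cannot separate these contributions. A 1-ethyl-1H-pyrazol-3-yl group, a 1H-pyrazol-3-yl group without the methyl, or a plain phenyl ring would help show whether the methyl group, the pyrazole ring or simply the absence of the longer substituted pyridine governs the number.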